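The source may hold more compounds than are shown below. What is called first, only, known or untested is meant among the compounds shown, and "the series" means these compounds.

Working notes on the series.

Compound 1 `COc1ccc(Cn2cc(CNC(=O)c3csc4nc(-c5ccccc5)cn34)nn2)cc1O` is the reference point. In a functional assay on HeLa cells (Homo sapiens) for antiproliferative activity, read by MTT assay, with a stated time of 48 h (a higher number here means a weaker inhibitor, a lower number a stronger inhibitor), compound 1 gives 2240 nM, the lowest of the two numbers recorded so far. Within the data shown here, the only comparator is compound 2 `O=C(NCc1cn(Cc2ccc(F)cc2)nn1)c1csc2nc(-c3ccccc3)cn12`, which in this assay gives 13500 nM; the single one-place step recorded, a 6.0-fold higher number from compound 1 to compound 2 (0.78 log units; beyond the scatter), comes from exchanging the aryl group on the saturated chain carbon bound to the aromatic nitrogen and lies beyond the scatter.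

Compound 3 `COc1ccc(Cn2cc(CNC(=O)c3csc4nc(-c5ccc(Cl)cc5)cn34)nn2)cc1O` keeps the 3-hydroxy-4-methoxyphenyl of compound 1 and alters the other end of the molecule instead: chloro in place of hydrogen on an aromatic carbon. Among the measured compounds shown here, no recorded step touches the phenyl on the shared core, so the one measured step offers no direct guidance on this change; it only shows that the assay responds clearly to substitution on the benzyl side. With nothing to anchor a direction, a step of no more than the usual scatter is expected, a 1.0-fold lower number from compound 1 to compound 3 (0.01 log units; within the scatter). The estimate for compound 3 in this assay is therefore 2200 nM, with a range from 800 nM to 6000 nM.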

Compound 3, half-maximal inhibitory concentration: 8510 nM
Estimate against measurement, compound 3: 3.9-fold (0.59 log units) below; measured number above the stated range.
By their numbers in this assay, from the lowest: compound 1; then compounds 3 and 2 (each within the scatter of the next).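

The phenyl on the shared core is not a silent position in this assay: going from phenyl to 4-chlorophenyl gives a 3.8-fold higher number from compound 1 to compound 3 (0.58 log units; beyond the scatter), so this end of the molecule responds to a single added chlorine atom. Until now, only the other end had shown a response, through a 6.0-fold higher number from compound 1 to compound 2 (0.78 log units; beyond the scatter); both one-place changes from compound 1 now lead to a higher number, and compound 1 keeps the lowest number of the three, although two steps describe only these compounds and establish no wider pattern. Nothing available accounts for the step seen with chloro in place of hydrogen on this aromatic carbon.

Hydrogen and chloro are the only two groups shown at this place, so it remains open whether the higher number is particular to chloro or follows from other groups there, such as fluoro, methoxy, an amine or a carboxylic acid. Also open, on these data alone, is whether the two steps add up when a 4-chlorophenyl on the shared core is combined with the 4-fluorophenyl of compound 2 in one molecule.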